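The source may hold more compounds than are shown below. What is called first, only, known or untested is meant among the compounds shown, and "the series" means these compounds.

Compound 1 `CC(C)n1ncc2c(C(=O)Nc3ccccc3)cccc21` carries a phenyl on the amide-type nitrogen and in a functional assay on HepG2 cells (Homo sapiens) for inhibition, read by MTT assay, with a stated time of 72 h (a higher number here means a weaker inhibitor, a lower number a stronger inhibitor), compound 1 gives 23700 nM. Compound 2 `CC(C)n1ncc2c(C(=O)NCc3ccccc3)cccc21` differs only by a benzyl in place of that phenyl, and in this assay compound 2 reaches only the limit of the assay, > 40000 nM. The change from compound 1 to compound 2 therefore gives an at least 1.6-fold higher number from compound 1 to compound 2 (0.22 log units; that floor lies within the scatter), and that step rests on the limit of > 40000 nM in this assay, at which 2 of the 3 values shown sit, rather than on a second number. Compound 3 `Cc1ccc(-n2cc(CNC(=O)c3cccc4c3cnn4C(C)C)nn2)c(C)c1` extends the benzyl idea into a larger group on the same nitrogen, and in this assay compound 3 likewise returns only the limit, > 40000 nM; of the three values shown, two are such limits, so compound 3 stands at the weak end without a number of its own. Compound 4 `CC(C)n1ncc2c(C(=O)NCc3cn(-c4cccc(F)c4)nn3)cccc21` keeps everything of compound 3 except one ring: 3-fluorophenyl in place of 2,4-dimethylphenyl on an aromatic nitrogen. No measured step touches this exchange, since the one step shown, from compound 1 to compound 2, concerns the amide-type nitrogen and not the aromatic nitrogen, and it too ends at a limit. The expected step from compound 3 to compound 4 is therefore a step that the limit leaves unreadable from compound 3 to compound 4, nothing beyond the scatter in either direction. For compound 4 the estimate in this assay is 50000 nM, with a range from 20000 nM to 150000 nM, and most likely again only a limit.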

Compound 4, half-maximal inhibitory concentration: > 40000 nM
Compound 4 gave a limit, no number; the forecaster's own chance of this, stated with the estimate: 75%; the middle value lies beyond the limit too.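

In this assay compound 4 returns only a limit, > 40000 nM. Compound 3 also stands at a limit, so no step from compound 3 to compound 4 can be read: the limit of > 40000 nM in this assay, at which 3 of the 4 values shown sit.

The compounds shown leave open whether 2,4-dimethylphenyl or 3-fluorophenyl on the aromatic nitrogen gives the lower number in this assay.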